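The source may hold more compounds than are shown below. What is called first, only, known or untested is meant among the compounds shown, and "the series" means these compounds.

Measured compounds:
Compound 1 `CSc1cnc2ccccc2c1SCC#CCOC(=O)/C=C/c1ccccc1` gives 18.1 ug/mL in a functional assay on CCRF-CEM cells (Homo sapiens) for antiproliferative activity, with a stated time of 72 h; on this read-out lower numbers stand for stronger inhibition and higher numbers for weaker inhibition.
Compound 2 `CCOC(=O)OCC#CCSc1c(SC)cnc2ccccc12` gives 13.2 ug/mL in this assay.

For the measured compounds named here, compound 2 holds the lowest of the two numbers so far in this assay, though its nearest neighbour, compound 1, is separated from it by a 1.4-fold lower number from compound 1 to compound 2 (0.14 log units; within the scatter), so the two are not distinguished. Compound 3 `CSc1cnc2ccccc2c1SCC#CCOC(=O)c1ccc(C(=O)O)cc1` has not yet been measured. It differs from compound 2 at the carbonyl carbon: 4-carboxyphenyl in place of ethoxy on a carbonyl carbon. Going by the values given here, the only measured step that bears on this position is the one from compound 1 to compound 2, which exchanged a group at the same carbonyl carbon and gave a 1.4-fold lower number from compound 1 to compound 2 (0.14 log units; within the scatter), a change within the scatter. Nothing measured shows how a 4-carboxyphenyl behaves here. Given the small effect of the earlier exchange, compound 3 is expected to land near compound 2, with a step of a 1.2-fold higher number from compound 2 to compound 3 (0.08 log units; within the scatter). The estimate for compound 3 is therefore 16 ug/mL, with a range from 7 ug/mL to 40 ug/mL.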

Compound 3, concentration for 50% inhibition: 14.5 ug/mL
Compound 3: middle estimate off by 1.1-fold (0.04 log units), on the high side; measured number inside the range.
By their numbers in this assay, from the lowest: compounds 2, 3 and 1 (each within the scatter of the next).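

In this assay the step of 4-carboxyphenyl in place of ethoxy on the carbonyl carbon is a 1.1-fold higher number from compound 2 to compound 3 (0.04 log units; within the scatter) and the step of 4-carboxyphenyl in place of 2-phenylethenyl is a 1.2-fold lower number from compound 1 to compound 3 (0.10 log units; within the scatter). For the compounds shown here, the earlier pair had only exchanged 2-phenylethenyl for ethoxy, so compound 3 adds a third group at this position, one that brings a carboxylic acid and a hydrogen-bond donor, and still no step among the three compounds lies beyond the scatter. Nothing available accounts for this lack of separation.

On these data alone, it remains open whether an amine in place of the carboxylic acid on the phenyl ring, or a longer alkyl chain in place of ethoxy, would move the number beyond the scatter. These compounds also share one core, so they say nothing about how changes to that core would read out.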